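From phenyl to 2-phenylethenyl on compound 3

The source may hold more compounds than are shown below. What is called first, only, known or untested is meant among the compounds shown, and "the series" means these compounds.

Of the compounds shown here, three built on one shared core have been tested in a functional assay on HCT-116 cells (Homo sapiens) for inhibition, read by MTT assay, with a stated time of 48 h; a higher number here means a weaker inhibitor, a lower number a stronger inhibitor. Compound 1 `Brc1ccccc1CSc1nnc(-c2ccncc2)n1-c1ccccc1` gives 20200 nM in this assay. Among the compounds with values here, compound 2 `O=[N+]([O-])c1cccc(CSc2nnc(-c3ccncc3)n2-c2ccccc2)c1` gives 19800 nM, and the only step between two compounds differing in one place, a 1.0-fold lower number from compound 1 to compound 2 (0.01 log units; within the scatter), lies within the scatter. Compound 3 `O=C(CSc1nnc(-c2ccncc2)n1-c1ccccc1)N/N=C/c1ccccc1` gives 14700 nM in this assay. Its gaps to compound 2 and to compound 1 are both within the scatter, so nothing separates the three on the numbers shown.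

Compound 4 `O=C(CSc1nnc(-c2ccncc2)n1-c1ccccc1)N/N=C/C=C/c1ccccc1` has not yet been measured. Relative to compound 3 it carries 2-phenylethenyl in place of phenyl on a carbon with a double bond to nitrogen. Within the data shown here, no measured step touches this carbon with a double bond to nitrogen: the one measured step, from compound 1 to compound 2, concerns a saturated chain carbon bound to a sulfur and was itself within the scatter. There is therefore no basis for expecting a step beyond the scatter in this assay, in either direction, and the expectation for compound 4 rests on the value of compound 3 alone. The estimate for compound 4 is 13000 nM, with a range from 5000 nM to 35000 nM. This corresponds to an expected step of a 1.1-fold lower number from compound 3 to compound 4 (0.05 log units; within the scatter).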

Compound 4, half-maximal inhibitory concentration: 6150 nM
Beside the measured number, compound 4's estimate is 2.1-fold (0.33 log units) above it; measured number inside the range.
By their numbers in this assay, from the lowest: compound 4; then compounds 3, 2 and 1 (each within the scatter of the next).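

In this assay, within the data shown here, the carbon with a double bond to nitrogen is the first place in this set where a single change moves the number beyond the scatter: 2-phenylethenyl in place of phenyl gives a modest step (a 2.4-fold lower number from compound 3 to compound 4 (0.38 log units; beyond the scatter)), whereas the only earlier step, at a saturated chain carbon bound to a sulfur, stayed within it (a 1.0-fold lower number from compound 1 to compound 2 (0.01 log units; within the scatter)). The entering group keeps the one six-membered aromatic ring of carbon only and adds a double bond outside aromatic rings, while neither group carries a hydrogen-bond donor or acceptor. Nothing available explains why the number falls with this change.

The compounds shown leave open whether the lower number depends on the double bond itself or only on the longer chain, a question that a saturated 2-phenylethyl group on this carbon would address. Also open, from the compounds shown here alone, is whether a still longer unsaturated chain, or an amine or a carboxylic acid on the phenyl ring of 2-phenylethenyl, would take the number further in either direction.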